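The source may hold more compounds than are shown below. What is called first, only, known or untested is meant among the compounds shown, and "the series" means these compounds.

Three compounds share one core and have been run through a functional assay on A549 cells (Homo sapiens) for cytotoxicity, read by MTT assay, with a stated time of 48 h; a lower number here means a stronger inhibitor, a higher number a weaker inhibitor. Compound 1 `CSc1nnc(C)n1N1C(=O)c2ccccc2C1=O` reaches in this assay only a limit, > 200000 nM. Compound 2 `Cc1nnc(SCc2ccccc2Cl)n1N1C(=O)c2ccccc2C1=O` likewise gives only a limit, > 200000 nM. Compound 3 `C#CCSc1nnc(CC)n1N1C(=O)c2ccccc2C1=O` also returns no number, only the limit > 200000 nM. The step that the two limits leave unreadable from compound 1 to compound 2 cannot be sized because the limit of > 200000 nM in this assay, at which 3 of the 3 values shown sit, leaves both ends of it hidden. Compound 3 therefore stands where every measured value in this series stands: at the limit, with no number to separate it from the others.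

Compound 4 `CCc1nnc(SCC(=O)c2ccc(Cl)cc2)n1N1C(=O)c2ccccc2C1=O` differs from compound 3 by (4-chlorophenyl)carbonyl in place of ethynyl on a saturated chain carbon bound to a sulfur. Within the data shown here, the only measured step, a step that the two limits leave unreadable from compound 1 to compound 2, touches the same position, a saturated chain carbon bound to a sulfur, and it too came out unreadable. Among the measured compounds shown here, no measured step supplies a size, and the three values all sit at the limit. For compound 4 the expectation in this assay is that it too remains at the limit, so the step of a number no higher from compound 3 to compound 4 (the limit leaves the size open) is expected to be none beyond the scatter. Compound 4 is accordingly estimated at 200000 nM, with a range from 50000 nM to 600000 nM.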

Compound 4, half-maximal inhibitory concentration: > 200000 nM
Compound 4: no number, only a limit; the forecaster's own chance of this, stated with the estimate: 85%; the middle value lies on the limit itself.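

Among these compounds, compound 3 and compound 4 give no number that could be compared, so no step between them can be read: the limit of > 200000 nM in this assay, at which 4 of the 4 values shown sit. What the compounds shown leave open is whether any group on a saturated chain carbon bound to a sulfur changes the result in this assay at all.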